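A few compounds are considered here, and "the series" means these few. Any claim that something is new, unique, unknown or untested is made for them only; others in the source may bear on it.

Compound 1 `COc1cc(-c2cc(/C=C/C(=O)c3ccc(N)cc3)[nH]n2)cc(OC)c1OC` is one of three compounds tested in a functional assay on RXF 393 cells (Homo sapiens) for cytotoxicity, read by sulforhodamine B assay, with a stated time of 48 h, tested at 10 uM (a lower number here means a stronger effect, a higher number a weaker effect of the compound at the concentration tested), where compound 1 gives -64%. That number is the second highest of the three: compound 2 `COc1ccc(-c2cc(/C=C/C(=O)c3ccc(OC)c(OC)c3)[nH]n2)cc1` gives -82%, and compound 3 `COc1ccc(-c2cc(/C=C/C(=O)c3ccc(N)cc3)[nH]n2)cc1OC` gives -39%. Among the compounds with values here, the only single-place step among them is a number 25 percentage points higher from compound 1 to compound 3 (beyond the scatter), which concerns hydrogen in place of methoxy on an aromatic carbon. Compound 4 `COc1cc(-c2cc(/C=C/C(=O)c3ccc(F)c(F)c3)[nH]n2)cc(OC)c1OC` differs from compound 1 elsewhere: 3,4-difluorophenyl in place of 4-aminophenyl on a carbonyl carbon. Within the data shown here, no measured step touches the group on the carbonyl carbon, so these compounds give no indication of the direction of this change, and the spread of the three numbers is the only guide. Compound 4 is therefore expected near -60%, between -95% and -20%. The step of a number 4 percentage points higher from compound 1 to compound 4 (within the scatter) is accordingly estimated to be small.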

Compound 4, a percentage reported as activity, at one concentration (the size of the read-out at that concentration, not a potency): -20%
Compound 4: middle estimate off by 40 percentage points, on the low side; low and high end bracket the measured number.
By their numbers in this assay, from the lowest: compound 2; then compound 1; then compound 3; then compound 4.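

Within the data shown here, the group on the carbonyl carbon proves to matter in this assay: 3,4-difluorophenyl in place of 4-aminophenyl gives a number 44 percentage points higher from compound 1 to compound 4 (beyond the scatter), a large weakening of the effect and the first measured step at this position. Nothing available explains this step.

From the compounds shown here alone, it remains open whether the weakening reflects the loss of 4-aminophenyl or the arrival of 3,4-difluorophenyl, and how a plain phenyl, a hydroxyphenyl or a dimethylaminophenyl would read on the core of compound 1. Going by these compounds, whether the step would keep its size on the core of compound 3 is also open.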